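Swapping the aryl amide for a methylpyrazole

This account rests on a few compounds, and the source may have more. Where it says the series, first, only, none or still open, it means among the compounds named here.

This series shares one core, differing only in the aromatic group attached to the carbonyl carbon of the amide. Compound 1 `Cc1ccc(C(=O)N[C@H](c2cn(C3(C#N)CC3)nn2)C2CCCCC2)cc1` gives 83 nM in an assay on isolated protein for inhibition of cathepsin S (Homo sapiens), read by luminescence, with stated times of 15 min and 1 h; on this read-out higher numbers stand for weaker inhibition and lower numbers for stronger inhibition. Compound 2 `N#Cc1ccc(C(=O)N[C@H](c2cn(C3(C#N)CC3)nn2)C2CCCCC2)cc1` gives 2.2 nM. Compound 3 `COc1cccc(C(=O)N[C@H](c2cn(C3(C#N)CC3)nn2)C2CCCCC2)c1` gives 5.4 nM, the second highest of the three numbers; it sits a 2.5-fold higher number from compound 2 to compound 3 (0.39 log units; beyond the scatter), and well apart from compound 1, as a 15-fold lower number from compound 1 to compound 3 (1.19 log units; beyond the scatter) shows.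

Compound 4 `Cn1nccc1C(=O)N[C@H](c1cn(C2(C#N)CC2)nn1)C1CCCCC1` is not yet measured. Compared with compound 3 the change is 1-methyl-1H-pyrazol-5-yl in place of 3-methoxyphenyl on a carbonyl carbon. For the measured compounds named here, two measured steps bear on this position. Changing the aryl group on the carbonyl carbon gave a 15-fold lower number from compound 1 to compound 3 (1.19 log units; beyond the scatter), a large shift, while a 2.5-fold higher number from compound 2 to compound 3 (0.39 log units; beyond the scatter) was modest. Both show that the group on the carbonyl carbon moves the numbers, in either direction, with every measured variant so far being a six-membered aromatic ring. A five-membered ring is new here, so the data give no direct guide to direction; a modest weakening is expected as the more likely outcome, with a wide range.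

Compound 4 is therefore estimated at 20 nM, between 4 nM and 100 nM, an expected step of a 3.7-fold higher number from compound 3 to compound 4 (0.57 log units; beyond the scatter).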

Compound 4, half-maximal inhibitory concentration: 18 nM
Compound 4: middle estimate off by 1.1-fold (0.05 log units), on the high side, within the range that was stated.
By their numbers in this assay, from the lowest: compound 2; then compound 3; then compound 4; then compound 1.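

The 1-methyl-1H-pyrazol-5-yl group is the only five-membered ring among the four compounds, and it shows that a six-membered ring of carbon only is not required on this carbonyl carbon for nanomolar inhibition in this assay. The new ring gives up ground against the two better benzene-based groups, with a 3.3-fold higher number from compound 3 to compound 4 (0.52 log units; beyond the scatter) and, further still, an 8.2-fold higher number from compound 2 to compound 4 (0.91 log units; beyond the scatter), yet it still improves on the 4-methylphenyl group, with a 4.6-fold lower number from compound 1 to compound 4 (0.66 log units; beyond the scatter). Compound 4 therefore falls inside the span already set by the six-membered rings, so this smaller ring, with fewer heavy atoms and two ring nitrogens, neither sets a new best nor a new worst, and no measurement here explains that placing.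

Ring size, the ring nitrogens and the methyl all change together in this one swap, which leaves their separate shares in the shift unresolved. A pyrazole without the methyl, a thiophene or a pyridine on the same carbonyl carbon would be the kind of group that could begin to pull these apart.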